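A pyridin-2-yl in place of 4-fluorophenyl

A few compounds are considered here, and "the series" means these few. Any claim that something is new, unique, unknown or untested is made for them only; others in the source may bear on it.

In a physicochemical assay for solubility (a higher number here means a more soluble compound, a lower number a less soluble compound), compound 3 `CNC(=O)c1cc(C(=O)N[C@H]2[C@@H]3COC[C@@H]32)cc2c1OC[C@H]2c1ccc(F)cc1` reads >= 176 ug/mL, which is a limit and not a number. Compound 2 `CNC(=O)c1cc(C(=O)N[C@H]2[C@@H]3COC[C@@H]32)cc2c1OC[C@H]2c1ccccc1` also gives only a limit, >= 165 ug/mL. Compound 1 `CNC(=O)c1cc(C(=O)N[C@H]2[C@@H]3COC[C@@H]32)cc2c1OC[C@H]2c1cccnc1` likewise gives only a limit, >= 104 ug/mL. None of the three therefore has a measured number, and compound 3 cannot be ranked against the other two.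

Compound 4 `CNC(=O)c1cc(C(=O)N[C@H]2[C@@H]3COC[C@@H]32)cc2c1OC[C@H]2c1ccccn1` carries pyridin-2-yl in place of 4-fluorophenyl on a saturated ring carbon. The nearest measured change is a step that the two limits leave unreadable from compound 1 to compound 3, which links 4-fluorophenyl with a different pyridine, pyridin-3-yl. Two further changes also bear on it: a step that the two limits leave unreadable from compound 1 to compound 2 and a step that the two limits leave unreadable from compound 2 to compound 3. None of these gives a size or a direction, so no step beyond the scatter is expected in this assay. The expected step is an at least 1.2-fold lower number from compound 3 to compound 4 (0.09 log units; that floor lies within the scatter). For compound 4 the estimate is 140 ug/mL, with an expected range of 70 ug/mL to 300 ug/mL.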

Compound 4, solubility: >= 158 ug/mL
Compound 4 ended at the assay's limit (the forecaster's own chance of this, stated with the estimate: 75%); middle value at least 1.1-fold (0.05 log units) from the limit.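

In this assay compound 4 reads >= 158 ug/mL, which is a limit and not a number. Going by these compounds alone, compound 1, compound 2 and compound 3 also give only limits, so no step to compound 4 can be read. The compounds shown leave open whether pyridin-2-yl, pyridin-3-yl, phenyl and 4-fluorophenyl differ at all in this read-out.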